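A few compounds are considered here, and "the series" means these few. Any claim that something is new, unique, unknown or untested is made for them only; others in the source may bear on it.

Compound 1 `COCn1c(CC(O)(COCc2ccccc2)COCc2ccccc2)cc(=O)[nH]c1=O`: in a functional assay on SW-620 cells (Homo sapiens) for antiproliferative activity, read by MTT assay, with a stated time of 72 h (on this read-out higher numbers stand for weaker inhibition and lower numbers for stronger inhibition), compound 1 gives > 100000 nM, which is a limit of the assay and not a number.
Compound 2 `C[Si](C)(C)CCOCn1c(CC(O)(COCc2ccccc2)COCc2ccccc2)cc(=O)[nH]c1=O`: in this assay compound 2 gives > 100000 nM, again a limit of the assay.
Compound 3 `Cc1c(CC(O)COCc2ccccc2)n(COCC[Si](C)(C)C)c(=O)[nH]c1=O`: in this assay compound 3 gives > 100000 nM, also a limit of the assay.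

Among the measured compounds shown here, all three values sit at the same limit (the limit of > 100000 nM in this assay, at which 3 of the 3 values shown sit), so no step between them can be read. The change from compound 2 to compound 1 is a hydrogen atom in place of a group of 5 heavy atoms (4 carbon, 1 silicon; no ring), on a saturated chain carbon bound to an oxygen on a saturated carbon; its step is a step that the two limits leave unreadable from compound 2 to compound 1. Compound 4 `COCn1c(CC(O)COCc2ccccc2)c(C)c(=O)[nH]c1=O` differs from compound 3 by the same change, (a hydrogen atom in place of a group of 5 heavy atoms (4 carbon, 1 silicon; no ring), on a saturated chain carbon bound to an oxygen on a saturated carbon). The difference between the cores of compound 2 and compound 3 is not broken down here.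

Since compound 1, compound 2 and compound 3 all sit at the limit (the limit of > 100000 nM in this assay, at which 3 of the 3 values shown sit), compound 4 is expected to sit there too, with the step that the limit leaves unreadable from compound 3 to compound 4 estimated to be unreadable. Compound 4 is expected to give about 200000 nM in this assay.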

Compound 4, half-maximal inhibitory concentration: > 100000 nM
Compound 4 gave a limit, no number; the forecaster's own chance of this, stated with the estimate: 90%; the middle value is on the limit's open side.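

No step can be read from compound 3 to compound 4, as each gives a limit of the assay and not a number: the limit of > 100000 nM in this assay, at which 4 of the 4 values shown sit.

The compounds shown leave open which structural change, if any, would give a measurable value against these cells.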